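Acetyl to phenylcarbamoyl on the pyrrolidine nitrogen

This account rests on a few compounds, and the source may have more. Where it says the series, first, only, none or still open, it means among the compounds named here.

Measured compounds:
Compound 1 `O=C(O)CN(Cc1ccc(Cl)cc1)Cc1ccc([N+](=O)[O-])s1` – in a functional assay on HEK293 cells for agonist activity at nuclear receptor subfamily 1 group D member 1 (Homo sapiens), read by a luciferase reporter, with a stated time of 24 h (on this read-out higher numbers stand for an effect only at larger amounts of compound and lower numbers for an effect already at smaller amounts), compound 1 is recorded as "not determined" (no result reported); no result reported.
Compound 2 `CC(=O)N1CCC(CN(Cc2ccc(Cl)cc2)Cc2ccc([N+](=O)[O-])s2)C1` – compound 2 gives 1600 nM in this assay.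

Compound 2 holds the only number shown; compound 1 carries no value, so no comparison between them is possible. Compound 3 `O=C(Nc1ccccc1)N1CCC(CN(Cc2ccc(Cl)cc2)Cc2ccc([N+](=O)[O-])s2)C1` differs from compound 2 by a single change: anilino in place of methyl on a carbonyl carbon. Among the measured compounds shown here, with no measured step of this kind to lean on, the author expects a modest gain beyond the usual scatter, a step of a 2.0-fold lower number from compound 2 to compound 3 (0.30 log units; within the scatter) in this assay. Compound 3 is therefore estimated at 800 nM, within a range of 250 nM to 3000 nM.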

Compound 3, half-maximal effective concentration: 620 nM
The estimate for compound 3 lay 1.3-fold (0.11 log units) above the measured number; the range from low to high includes it.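

In this assay, among the compounds shown here, anilino in place of methyl on a carbonyl carbon gives a 2.6-fold lower number from compound 2 to compound 3 (0.41 log units; beyond the scatter) and so provides the first measured step at this position. It shows that this carbonyl carbon accepts the much larger anilino group, with its six-membered aromatic ring and hydrogen-bond donor, without any loss. Nothing measured here accounts for the step.

From the compounds shown here alone, what a methylamino or a benzyl group on this carbonyl carbon would give remains open. So does whether the aromatic ring or the amide hydrogen of the anilino group carries the step.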